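Paw edema series: fluorophenyl to dihydroxyphenyl hydrazone

A few compounds are considered here, and "the series" means these few. Any claim that something is new, unique, unknown or untested is made for them only; others in the source may bear on it.

Compound 1 `O=C(N/N=C/c1ccccc1)c1cccnc1Nc1cccc(C(F)(F)F)c1` and compound 2 `O=C(N/N=C/c1ccc(F)cc1)c1cccnc1Nc1cccc(C(F)(F)F)c1` share one core and differ only in the aryl of the hydrazone. For the measured compounds named here, in a functional assay on the whole organism (strain Wistar) for inhibition, with Rattus norvegicus as the target, read by paw edema, with a stated time of 3 h, at a dose of 10 mg/kg by the intraperitoneal route (on this read-out lower numbers stand for less inhibition and higher numbers for more inhibition at the one dose given (going by the name of the read-out)), compound 1 gives 21.2% and compound 2 gives 41.3%, so compound 2 stands highest of the two numbers, with a number 20.1 percentage points higher from compound 1 to compound 2 (beyond the scatter) as the single step seen so far.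

Compound 3 `O=C(N/N=C/c1ccc(O)c(O)c1)c1cccnc1Nc1cccc(C(F)(F)F)c1` carries the change (3,4-dihydroxyphenyl in place of 4-fluorophenyl on a carbon with a double bond to nitrogen). Going by the values given here, no measured step covers an exchange of this kind; the one step available, hydrogen to fluoro on the aromatic carbon, bears only loosely on it, as it shows that this aryl position is sensitive to substitution. The expected step in this assay is therefore small, in either direction, and likely within the scatter; it is estimated as a number 3.3 percentage points lower from compound 2 to compound 3 (within the scatter). Compound 3 is expected to give 38%, with a range from 18% to 58%.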

Compound 3, a percentage reported as inhibition, in the whole organism at one dose (the size of the read-out at that dose, not a potency): 38.2%
The estimate for compound 3 lay 0.2 percentage points below the measured number; low and high end bracket the measured number.
By their numbers in this assay, from the lowest: compound 1; then compounds 3 and 2 (each within the scatter of the next).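

In this assay the exchange on the carbon with a double bond to nitrogen gives a number 3.1 percentage points lower from compound 2 to compound 3 (within the scatter), so an aryl with hydrogen-bond donors and acceptors and one with neither cannot be told apart at this position. Set against the plain phenyl, 3,4-dihydroxyphenyl gives a number 17 percentage points higher from compound 1 to compound 3 (beyond the scatter), which makes it a second substituted aryl, after 4-fluorophenyl, that stands beyond the scatter from compound 1. No measurement at hand accounts for two such different aryls reading alike.

From the compounds shown here alone, whether an aryl with a single hydroxyl, a methoxy group, an amine or a carboxylic acid would stand with compound 2 and compound 3 remains open. Going by these compounds, with one dose only, any difference in potency also remains open.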